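The source may report more compounds than this note shows. Statements on the series, on what has been measured and on what is new or still open speak of the compounds shown alone.

Measured in a functional assay on P388 cells (Mus musculus) for cytotoxicity; on this read-out lower numbers stand for stronger inhibition and higher numbers for weaker inhibition:
- compound 1 `COC(=O)C[C@@H]1NC(=O)[C@@H](C)NC(=O)[C@@H]2Cc3ccc(OC)c(c3)Oc3ccc(cc3)C[C@@H](C(=O)N2C)N(C)C(=O)[C@H](C)NC(=O)[C@H](Cc2ccc(OC)cc2)N(C)C1=O`: 41.7 nM
- compound 2 `C=CC[C@@H]1NC(=O)[C@@H](C)NC(=O)[C@@H]2Cc3ccc(OC)c(c3)Oc3ccc(cc3)C[C@@H](C(=O)N2C)N(C)C(=O)[C@H](C)NC(=O)[C@H](Cc2ccc(OC)cc2)N(C)C1=O`: 38.9 nM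
- compound 3 `COc1ccc(C[C@H]2C(=O)N[C@@H](C)C(=O)N(C)[C@H]3Cc4ccc(cc4)Oc4cc(ccc4OC)C[C@@H](C(=O)N[C@H](C)C(=O)N[C@@H](CC(=O)O)C(=O)N2C)N(C)C3=O)cc1`: 1200 nM

Compound 3 has the highest number of the three. Compound 4 `COc1ccc(C[C@H]2C(=O)N[C@@H](C)C(=O)N(C)[C@H]3Cc4ccc(cc4)Oc4cc(ccc4OC)C[C@@H](C(=O)N[C@H](C)C(=O)N[C@@H](CCO)C(=O)N2C)N(C)C3=O)cc1` differs from it as follows: hydroxymethyl in place of carboxy on a saturated chain carbon bound to a saturated ring carbon. This puts hydroxymethyl in place of carboxy on a saturated chain carbon bound to a saturated ring carbon. Among the measured compounds shown here, two measured steps bear on this change, a 29-fold higher number from compound 1 to compound 3 (1.46 log units; beyond the scatter) and a 31-fold higher number from compound 2 to compound 3 (1.49 log units; beyond the scatter). Both are large and both end at the carboxy compound, while a 1.1-fold lower number from compound 1 to compound 2 (0.03 log units; within the scatter) shows that the two non-acid side chains do not separate. For the measured compounds named here, no hydroxyl-bearing compound has been measured, so the recovery is expected to be large but perhaps incomplete. The expected change is a move to a lower number, a 12-fold lower number from compound 3 to compound 4 (1.08 log units; beyond the scatter). Compound 4 is estimated at 100 nM, with an expected range of 30 nM to 400 nM.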

Compound 4, half-maximal inhibitory concentration: 60.3 nM
Beside the measured number, compound 4's estimate is 1.7-fold (0.22 log units) above it; measured number inside the range.
By their numbers in this assay, from the lowest: compounds 2, 1 and 4 (each within the scatter of the next); then compound 3.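

In this assay hydroxymethyl in place of carboxy on a saturated chain carbon bound to a saturated ring carbon gives a 20-fold lower number from compound 3 to compound 4 (1.30 log units; beyond the scatter) and so reverses the loss seen with the acid. A hydroxyl-bearing side chain does not separate from the vinyl or methoxycarbonyl side chains, with a 1.6-fold higher number from compound 2 to compound 4 (0.19 log units; within the scatter) and a 1.4-fold higher number from compound 1 to compound 4 (0.16 log units; within the scatter), so among these compounds only the carboxy compound stands apart. Nothing available here explains why this position behaves this way. Still open, from the compounds shown here alone, is whether an amine or a longer chain ending in hydroxyl would stay with compound 4 or move towards compound 3.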